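Replacing a sulfonyl group where only limits are known

The source may hold more compounds than are shown below. What is called first, only, known or untested is meant among the compounds shown, and "the series" means these compounds.

In an ADME assay on HepG2 cells (Homo sapiens) for cytotoxicity, read by MTT assay, with a stated time of 48 h (a lower number here means a stronger inhibitor, a higher number a weaker inhibitor), compound 1 `O=S(=O)(c1cccc(-c2ccc3ncnc(Nc4ccc(OCc5cccc(F)c5)c(Cl)c4)c3c2)c1)N1CCCC1` gives > 15000 nM as a limit and not a number. Compound 2 `COc1ccc(Nc2ncnc3ccc(-c4ccc(S(=O)(=O)N5CCOCC5)cc4)cc23)cc1Cl` gives > 15000 nM as a limit too. Compound 3 `O=S(=O)(c1ccc(-c2ccc3ncnc(Nc4ccc(OCc5cccc(Cl)c5)c(Cl)c4)c3c2)cc1)N1CCOCC1` gives > 15000 nM as a limit as well. For the measured compounds named here, the one measured step is a step that the two limits leave unreadable from compound 2 to compound 3 and it lies elsewhere in the molecule, so it offers no size or direction to carry over. Compared with compound 1, compound 4 `Fc1cccc(COc2ccc(Nc3ncnc4ccc(-c5cccc(N6CCCCC6)c5)cc34)cc2Cl)c1` has piperidin-1-yl in place of (pyrrolidin-1-yl)sulfonyl on an aromatic carbon. Compound 4 is expected to stay in the same region of this assay because of the limit of > 15000 nM in this assay, at which 3 of the 3 values shown sit, and no change beyond the scatter is foreseen. The estimated change is a step that the limit leaves unreadable from compound 1 to compound 4 and it remains tentative. Compound 4 is estimated at 20000 nM with 9000 nM to 45000 nM as its expected range.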

Compound 4, half-maximal inhibitory concentration: > 15000 nM
Compound 4: only a limit was reported (the forecaster's own chance of this, stated with the estimate: 75%); the middle value lies beyond the limit too.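

In this assay compound 4 gives > 15000 nM, a limit and not a number. For the compounds shown here, no step from compound 1 to compound 4 can be read. The compounds shown leave open what size or direction, if any, the change to piperidin-1-yl has in this assay.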